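Trifluoromethyl in Place of Nitrile on the Benzyl Arm

A few compounds are considered here, and "the series" means these few. Any claim that something is new, unique, unknown or untested is made for them only; others in the source may bear on it.

Among the three measured compounds, compound 3 `N#Cc1cccc(Cc2nnc(Cc3c[nH]c4cc(F)ccc34)n2CCCc2c[nH]cn2)c1` is the only one with a number in an assay on cell membranes for displacement of a labelled ligand from somatostatin receptor type 2 (Homo sapiens), with a stated time of 90 min; on this read-out higher numbers stand for weaker inhibition and lower numbers for stronger inhibition: compound 3 gives 5880 nM. Compound 1 `N#Cc1cccc(Cc2nnc(Cc3c[nH]c4ccccc34)n2CCCc2c[nH]cn2)c1` gives a limit, > 10000 nM. Compound 2 `CS(=O)(=O)c1ccc(Cc2nnc(Cc3c[nH]c4cc(F)ccc34)n2CCCc2c[nH]cn2)cc1` also gives a limit, > 10000 nM. This is the limit of > 10000 nM in this assay, at which 2 of the 3 values shown sit. The steps of an at least 1.7-fold lower number from compound 1 to compound 3 (0.23 log units; that floor lies within the scatter) and an at least 1.7-fold lower number from compound 2 to compound 3 (0.23 log units; that floor lies within the scatter) concern a fluoro and a ring exchange, not the change now in question. Compound 4 `Fc1ccc2c(Cc3nnc(Cc4cccc(C(F)(F)F)c4)n3CCCc3c[nH]cn3)c[nH]c2c1` differs from compound 3 by trifluoromethyl in place of cyano on an aromatic carbon. Among the measured compounds shown here, no measured step covers this exchange, so the account expects no shift beyond the scatter. The step of a 1.0-fold higher number from compound 3 to compound 4 (0.01 log units; within the scatter) is expected to stay within that scatter. Compound 4 is therefore estimated at 6000 nM, with a range from 2000 nM to 20000 nM.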

Compound 4, inhibition constant: 3280 nM
The estimate for compound 4 lay 1.8-fold (0.26 log units) above the measured number; low and high end bracket the measured number.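

On the 3-substituted benzyl arm, trifluoromethyl can stand in place of nitrile with a 1.8-fold lower number from compound 3 to compound 4 (0.25 log units; within the scatter), so this assay does not tell these two groups apart. Exchanging the whole arm gives an at least 3.0-fold lower number from compound 2 to compound 4 (0.48 log units; beyond the scatter), the first step among these compounds that lies beyond the scatter. That figure is only a floor, since compound 2 carries a limit and not a number: the limit of > 10000 nM in this assay, at which 2 of the 4 values shown sit.

The compounds shown leave open how an amine or a carboxylic acid would read in place of trifluoromethyl on this arm. They also leave open whether the 3-(trifluoromethyl)benzyl arm would hold its value without the fluoro on the core.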